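Furan-3-yl for phenyl on a nucleoside series

The source may report more compounds than this note shows. Statements on the series, on what has been measured and on what is new or still open speak of the compounds shown alone.

Measured compounds:
compound 1, `COc1nc(N)nc2c1c(-c1ccccc1)cn2[C@@H]1O[C@H](CO)[C@@H](O)[C@H]1O`: in a functional assay on CCRF-CEM cells (Homo sapiens), read by MTT assay, with a stated time of 72 h (a higher number here means a weaker inhibitor, a lower number a stronger inhibitor), compound 1 gives only a limit, > 20000 nM.
compound 2, `Nc1nc(N)c2c(-c3ccccc3)cn([C@@H]3O[C@H](CO)[C@@H](O)[C@H]3O)c2n1`: in this assay compound 2 gives only a limit, > 20000 nM.
compound 3, `COc1ncnc2c1c(-c1ccccc1)cn2[C@@H]1O[C@H](CO)[C@@H](O)[C@H]1O`: in this assay compound 3 gives only a limit, > 20000 nM.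

Compound 1 stands at the limit of this assay, and so does every other value shown: the limit of > 20000 nM in this assay, at which 3 of the 3 values shown sit. The two measured changes on the shared core of compound 1 are therefore unreadable in size. The step that the two limits leave unreadable from compound 1 to compound 2 cannot be sized from the two limits, and the step that the two limits leave unreadable from compound 1 to compound 3 cannot either. No ordering of compound 1, compound 2 and compound 3 can be made from these numbers.

Compound 4, `COc1nc(N)nc2c1c(-c1ccoc1)cn2[C@@H]1O[C@H](CO)[C@@H](O)[C@H]1O`, differs from compound 1 in one place: furan-3-yl in place of phenyl on an aromatic carbon. Neither measured step touches this position, and both are unreadable, so there is no measured evidence on the size or direction of the change from phenyl to furan-3-yl in this assay. With every compound shown sitting at the limit, compound 4 is expected to return a limit as well. The estimate for compound 4 in this assay is 30000 nM, with a range from 10000 nM to 100000 nM. The step expected from compound 1 to compound 4 is a step that the limit leaves unreadable from compound 1 to compound 4, not readable beyond the scatter if both remain at the limit.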

Compound 4, half-maximal inhibitory concentration: > 20000 nM
Compound 4: only a limit was reported; the forecaster's own chance of this, stated with the estimate: 85%; the middle value lies beyond the limit too.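

In this assay compound 4 gives only a limit, > 20000 nM. No step can be read from compound 1 to compound 4, and furan-3-yl and phenyl stay unranked: the limit of > 20000 nM in this assay, at which 4 of the 4 values shown sit. The compounds shown leave open whether any change on the shared core of compound 1 would give a measurable value in this assay.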